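Swapping methoxy for chloro on the phenoxy ring

The compounds below may be only part of what the source reports. "The series", "measured", "known", "first", "only" and "open" are said of these compounds alone.

Of the compounds shown here, three have been tested in an in vitro assay on SH-SY5Y cells for displacement of a labelled ligand from Neuronal acetylcholine receptor; alpha3/beta4 (Homo sapiens); on this read-out lower numbers stand for stronger inhibition and higher numbers for weaker inhibition. Compound 1 `COc1cc(C2=CC3CC(C2)CN(C)C3)cnc1Cl` gives 1430 nM, and compound 2 `CN1CC2C=C(c3cncc(C#N)c3)CC(C2)C1` gives 4500 nM. Compound 3 `COc1ccccc1Oc1cncc(C2=CC3CNCC(C2)C3)c1` gives 56 nM, the lowest of the three numbers, separated from both compound 1 and compound 2 by gaps that lie well beyond the scatter. Compound 4 `Clc1ccccc1Oc1cncc(C2=CC3CNCC(C2)C3)c1` has not yet been measured in this assay. It differs from compound 3 in one place: chloro in place of methoxy on an aromatic carbon. Among the measured compounds shown here, no measured pair shows this change, so its effect is unknown here. Given compound 3 at 56 nM, the step from compound 3 to compound 4 is expected to be small, a 1.3-fold higher number from compound 3 to compound 4 (0.10 log units; within the scatter), not beyond the scatter in either direction. Compound 4 is therefore estimated at 70 nM, with a range from 25 nM to 200 nM.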

Compound 4, inhibition constant: 26 nM
For compound 4 the middle estimate is 2.7-fold (0.43 log units) above the measured one, and the stated range covers the measured number.
By their numbers in this assay, from the lowest: compound 4; then compound 3; then compound 1; then compound 2.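

In this assay, going from 2-methoxyphenyl to 2-chlorophenyl gives a 2.2-fold lower number from compound 3 to compound 4 (0.33 log units; beyond the scatter), a modest step. It shows that the methoxy group, on an aromatic carbon ortho to a large group, can give way to chloro, with one heavy atom and no hydrogen-bond acceptor, without the number rising. Nothing shown accounts for the size or direction of this step.

Going by these compounds, whether fluoro, methyl, hydroxyl or an amine at this place would follow chloro remains open. So does whether the same swap would give a lower number on any other core.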